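Expected Maximal Response After a Change on the Amide Nitrogen

The compounds below may be only part of what the source reports. "The series", "measured", "known", "first", "only" and "open" are said of these compounds alone.

Compound 1, `COc1ccccc1-c1ccc(CNC(=O)NC2CCN(Cc3ccc(C)cc3)CC2)cc1`, reaches 99.5% in an in vitro functional assay on HEK293 cells for antagonist activity at melanin-concentrating hormone receptor 1 (Homo sapiens); a higher number here means a larger maximal response, a lower number a smaller maximal response.
Compound 2, `Cc1ccc(CN2CCC(NC(=O)NCc3ccc(-c4cccc(C#N)c4)cc3)CC2)cc1`, reaches 98% in this assay.
Compound 3, `Cc1ccc(CN2CCC(NC(=O)NCc3ccc(-c4ccccc4)cc3)CC2)cc1`, reaches 124% in this assay.

Among these three numbers compound 1 stands second highest. Its nearest neighbour is compound 2, with a number 1.5 percentage points lower from compound 1 to compound 2 (within the scatter), so the two are indistinguishable here. Its furthest is compound 3, with a number 24.5 percentage points higher from compound 1 to compound 3 (beyond the scatter), a modest rise that is real. The third step, a number 26 percentage points higher from compound 2 to compound 3 (beyond the scatter), is of the same kind.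

Compound 4, `COc1ccccc1-c1ccc(CN(CC(=O)C(C)(C)O)C(=O)NC2CCN(Cc3ccc(C)cc3)CC2)cc1`, is the compound still to be measured. It differs from compound 1 in a single place: ((1-hydroxy-1-methylethyl)carbonyl)methyl in place of hydrogen on an amide-type nitrogen.

All three measured steps swap a group on an aromatic carbon of the outer ring; none of them alters the amide-type nitrogen where the new chain of compound 4 enters. So no measured step bears directly on this change, and the only guide is that the three known compounds all sit near or above the reference level in this assay. The expected step is therefore small, a number 6.5 percentage points lower from compound 1 to compound 4 (within the scatter), with no direction that can be read from the data. Compound 4 is estimated to reach 93% in this assay, within a range from 70% to 115%.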

Compound 4, largest response reached (reported as Imax), in percent of the reference or control that the assay uses: 68.3%
The estimate for compound 4 lay 24.7 percentage points above the measured number; the measured number lies below the stated range.
By their numbers in this assay, from the lowest: compound 4; then compounds 2 and 1 (each within the scatter of the next); then compound 3.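

Putting the ((1-hydroxy-1-methylethyl)carbonyl)methyl chain in place of the amide hydrogen gives a number 31.2 percentage points lower from compound 1 to compound 4 (beyond the scatter) in this assay, the only change from compound 1 shown here that lowers the number beyond the scatter, and the first to touch this amide-type nitrogen rather than the outer aromatic ring. So this nitrogen is a place where a substitution can clearly alter the maximal response, yet the response does not vanish, as compound 4 still gives 68.3%. Nothing measured here tells which part of the chain accounts for the drop, or how it arises.

From the compounds shown here alone, with only one substituent on this nitrogen, it remains open whether any group there lowers the number: a plain methyl group, an unbranched propyl chain, or a chain ending in an amine or a carboxylic acid would help separate the presence of a substituent from the particular carbonyl and hydroxyl groups of this one. Going by these compounds, it is also open whether the same chain would lower the number to a similar extent on the nitrogen of compound 3.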